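A few compounds are considered here, and "the series" means these few. Any claim that something is new, unique, unknown or untested is made for them only; others in the source may bear on it.

For the measured compounds named here, the set rests on one shared core, and in a functional assay on HeLa cells (Homo sapiens) for antiproliferative activity, read by MTT assay, with a stated time of 72 h (a higher number here means a weaker inhibitor, a lower number a stronger inhibitor), none of the three measured members yields a number. Compound 1 `C[Si](C)(C)CCOCn1c(CC(O)(CO)CO)cc(=O)[nH]c1=O` carries a triol chain on the core. In this assay compound 1 gives only a limit, > 100000 nM. Compound 2 `O=c1cc(CC(O)COCc2ccccc2)[nH]c(=O)[nH]1` carries a chain bearing a (benzyloxy)methyl on an otherwise bare core. In this assay compound 2 likewise gives only a limit, > 100000 nM. Compound 3 `C[Si](C)(C)CCOCn1c(CC(O)COCc2ccccc2)cc(=O)[nH]c1=O` adds to compound 2 a group on the aromatic nitrogen. In this assay compound 3 also gives only a limit, > 100000 nM. Going by the values given here, the single measured step, a step that the two limits leave unreadable from compound 2 to compound 3, is thus not readable, and compound 3 stands where all measured members stand, at the limit of > 100000 nM in this assay, at which 3 of the 3 values shown sit.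

Compound 4 `C[Si](C)(C)CCOCn1c(CC(O)CO)cc(=O)[nH]c1=O` differs from compound 3 in one place: hydrogen in place of benzyl on an oxygen on a saturated carbon, so the (benzyloxy)methyl of the chain becomes a hydroxymethyl. Among the compounds with values here, no measured step touches this oxygen, and the one step that was measured carries no readable size, so the step is expected to be none beyond the scatter, a step that the limit leaves unreadable from compound 3 to compound 4. On this basis compound 4 is expected, like its three measured relatives, to reach only the limit of this assay. The estimate for compound 4 is 150000 nM, within a range from 50000 nM to 500000 nM.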

Compound 4, half-maximal inhibitory concentration: > 100000 nM
Compound 4: no number, only a limit; the forecaster's own chance of this, stated with the estimate: 85%; the middle value is on the limit's open side.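

Compound 4, like compound 1 and compound 3, gives only a limit in this assay, so neither the step from compound 3 to compound 4 nor the step from compound 1 to compound 4 can be read: the limit of > 100000 nM in this assay, at which 4 of the 4 values shown sit. The compounds shown leave open whether any change on the shared core would give a measurable value in this assay.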